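The source may hold more compounds than are shown below. What is called first, only, known or untested is meant among the compounds shown, and "the series" means these compounds.

Measured compounds:
- compound 1 `C=C1CC[C@@H]2[C@](C)(CO)[C@H](O)CC[C@@]2(C)[C@@H]1C/C=C1/C(=O)OC[C@H]1OC(=O)CSc1ccc([N+](=O)[O-])cc1` gives 17000 nM in a functional assay on PC-3 cells (Homo sapiens) for inhibition, read by MTT assay, with a stated time of 48 h; on this read-out higher numbers stand for weaker inhibition and lower numbers for stronger inhibition
- compound 2 `C=C1CC[C@@H]2[C@](C)(CO)[C@H](O)CC[C@@]2(C)[C@@H]1C/C=C1/C(=O)OC[C@H]1OC(=O)CCCSc1ccc(OC)cc1` gives 19000 nM in this assay

Going by the values given here, compound 2 holds the highest of the two numbers; its nearest neighbour is compound 1, and the single measured step, a 1.1-fold higher number from compound 1 to compound 2 (0.05 log units; within the scatter), lies within the scatter. That step changes two things at once, the chain length and the group on the ring, so it does not isolate either.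

Compound 3 `C=C1CC[C@@H]2[C@](C)(CO)[C@H](O)CC[C@@]2(C)[C@@H]1C/C=C1/C(=O)OC[C@H]1OC(=O)CCCSc1ccc([N+](=O)[O-])cc1` differs from compound 2 only on the ring: nitro in place of methoxy on an aromatic carbon, para to a large group. Among the compounds with values here, no measured step bears on this change alone; the step from compound 1 to compound 2 is the only related one, and it was within the scatter despite two changes. No step beyond the scatter is therefore expected in this assay, and the expected step is a 1.1-fold lower number from compound 2 to compound 3 (0.05 log units; within the scatter).

Compound 3 is estimated at 17000 nM, with a range of 8000 nM to 36000 nM.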

Compound 3, half-maximal inhibitory concentration: 17000 nM
For compound 3 middle estimate and measured number coincide at the digits printed; measured number inside the range.
By their numbers in this assay, from the lowest: compounds 1, 3 and 2 (each within the scatter of the next).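

In this assay the ring group can now be read alone: nitro in place of methoxy on an aromatic carbon, para to a large group, gives a step within the scatter (a 1.1-fold lower number from compound 2 to compound 3 (0.05 log units; within the scatter)). The chain can also be read alone, with the 4-nitrophenyl group held fixed: 2-((4-nitrophenyl)sulfanyl)ethyl in place of (4-nitrophenyl)sulfanyl gives no change at the digits printed from compound 1 to compound 3 (within the scatter) and also stays within the scatter. The earlier step combined these two changes, and each now stands within the scatter on its own, though nothing available gives a cause for this.

Open, from the compounds shown here alone, is whether an amine or a carboxylic acid on this aromatic carbon, or a longer chain, would give a step beyond the scatter. The compounds shown also leave open whether any change to the shared core would do so.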